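A few compounds are considered here, and "the series" means these few. Any claim that something is new, unique, unknown or untested is made for them only; others in the source may bear on it.

Working notes on the substituent at one place in the series, a saturated chain carbon bound to a double-bonded ring carbon. Among the measured compounds shown here, in a functional assay on HL-60 cells (Homo sapiens) for antiproliferative activity, read by MTT assay, with a stated time of 48 h (on this read-out lower numbers stand for stronger inhibition and higher numbers for weaker inhibition), compound 2 `CC[Si](CC)(CC)C/C1=C/C[C@](C)(CCC=C(C)C)/C=C/[C@@H](OC(=O)C=C(C)C)[C@](C)(O)/C=C/C1=O` gives 2810 nM, the higher of the two numbers so far, and compound 1 `CC(C)=CCC[C@]1(C)/C=C/[C@@H](OC(=O)C=C(C)C)[C@](C)(O)/C=C/C(=O)/C(CN2CCCC2)=C\C1` gives 160 nM. Compound 3 `CC(C)=CCC[C@]1(C)/C=C/[C@@H](OC(=O)C=C(C)C)[C@](C)(O)/C=C/C(=O)/C(COC(=O)c2ccc([N+](=O)[O-])cc2)=C\C1` is still unmeasured. Its difference from compound 2 is a group of 12 heavy atoms (7 carbon, 1 nitrogen, 4 oxygen; one six-membered aromatic ring of carbon only) in place of a group of 7 heavy atoms (6 carbon, 1 silicon; no ring), on a saturated chain carbon bound to a double-bonded ring carbon, and the entering group is ((4-nitrophenyl)carbonyl)oxy. For the measured compounds named here, only one measured step bears on this change, at the same place: an 18-fold higher number from compound 1 to compound 2 (1.24 log units; beyond the scatter), which is large and beyond the scatter. No group of the entering kind has been measured, so that step is a loose guide. A moderate move toward lower numbers is expected, smaller than that step. The expected step is a 3.1-fold lower number from compound 2 to compound 3 (0.49 log units; beyond the scatter). For compound 3 the estimated value is 900 nM, with an expected range of 200 nM to 3500 nM.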

Compound 3, half-maximal inhibitory concentration: 830 nM
The estimate for compound 3 lay 1.1-fold (0.04 log units) above the measured number; measured number inside the range.
By their numbers in this assay, from the lowest: compound 1; then compound 3; then compound 2.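

In this assay the third substituent at this place, ((4-nitrophenyl)carbonyl)oxy, lands between the other two groups: the number falls on replacing the silicon-bearing group (a 3.4-fold lower number from compound 2 to compound 3 (0.53 log units; beyond the scatter)) but rises against pyrrolidin-1-yl (a 5.2-fold higher number from compound 1 to compound 3 (0.71 log units; beyond the scatter)). The order therefore does not follow heavy-atom count, since the entering group is the largest of the three yet stands in the middle, and an aromatic ring and hydrogen-bond acceptors at this place do not match the low number of the pyrrolidine-bearing compound 1. Nothing measured accounts for this order. Still open, going by these compounds, is whether the nitrogen or the ring of pyrrolidin-1-yl goes with the lowest number, which dimethylamino, piperidin-1-yl or a plain cyclopentyl group at this place would help separate. Also open, on these data alone, is what the nitro group contributes, which an unsubstituted benzoyloxy group would address.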